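Swapping the aryl group on the chalcone-like ketone: compound 4

A few compounds are considered here, and "the series" means these few. Any claim that something is new, unique, unknown or untested is made for them only; others in the source may bear on it.

Within the data shown here, the shared core of this small set is a stilbene carrying a conjugated ketone, and the three measured members differ only in the aryl group attached to the carbonyl carbon. Compound 1 `COc1ccc(/C=C/c2cc(OC)cc(OC)c2/C=C/C(=O)c2cccc(Br)c2)cc1`, in a functional assay on A549 cells (Homo sapiens) for antiproliferative activity, read by MTT assay, with a stated time of 48 h (a higher number here means a weaker inhibitor, a lower number a stronger inhibitor), gives 8.1 ug/mL; compound 2 `COc1ccc(/C=C/c2cc(OC)cc(OC)c2/C=C/C(=O)c2ccc(Br)cc2)cc1` gives 8.3 ug/mL, and compound 3 `COc1ccc(/C=C/c2cc(OC)cc(OC)c2/C=C/C(=O)c2ccc(C(F)(F)F)cc2)cc1` gives 7.8 ug/mL. Compound 1 thus sits in the middle of three numbers that are all within the scatter of one another: a 1.0-fold higher number from compound 1 to compound 2 (0.01 log units; within the scatter), a 1.0-fold lower number from compound 1 to compound 3 (0.02 log units; within the scatter), a 1.1-fold lower number from compound 2 to compound 3 (0.03 log units; within the scatter).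

Compound 4 `CCN(CC)c1ccc(C(=O)/C=C/c2c(/C=C/c3ccc(OC)cc3)cc(OC)cc2OC)cc1` is the next member, not yet measured. Relative to compound 1 the change is 4-(diethylamino)phenyl in place of 3-bromophenyl on a carbonyl carbon. Among the measured compounds shown here, none of the measured steps involves this group, so they bear on it only indirectly: each showed that exchanging the aryl substituent left the numbers unchanged beyond the scatter. On that basis no step beyond the scatter is expected, and the estimated step is a 1.0-fold higher number from compound 1 to compound 4 (0.02 log units; within the scatter). Compound 4 is therefore expected to give about 8.5 ug/mL, with a range from 4 ug/mL to 18 ug/mL.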

Compound 4, half-maximal inhibitory concentration: 5.4 ug/mL
Compound 4: the middle estimate sits 1.6-fold (0.20 log units) above what was measured, within the range that was stated.
By their numbers in this assay, from the lowest: compounds 4, 3, 1 and 2 (each within the scatter of the next).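

In this assay, among these compounds, the earlier steps exchanged only bromo and trifluoromethyl, whereas compound 4 shows that the aryl group on the carbonyl carbon can also be 4-(diethylamino)phenyl, which brings in a nitrogen and more heavy atoms, with the number staying close: a 1.5-fold lower number from compound 1 to compound 4 (0.18 log units; within the scatter). The same holds for the other two comparisons, a 1.4-fold lower number from compound 3 to compound 4 (0.16 log units; within the scatter) and a 1.5-fold lower number from compound 2 to compound 4 (0.19 log units; within the scatter), so these four aryl groups cannot be told apart by this read-out. Nothing measured here points to a cause for this result.

From the compounds shown here alone, whether a carboxylic acid or a primary amine in place of diethylamino would carry the number beyond the scatter remains open. So does whether a plain alkyl chain could replace the whole aryl group on the carbonyl carbon.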